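The source may hold more compounds than are shown below. What is called first, only, known or untested is meant among the compounds shown, and "the series" means these compounds.

Measured compounds:
compound 1, `CN1CCN(C(=S)SCc2coc3ccccc3c2=O)CC1`: 5900 nM
compound 2, `O=c1c(CSC(=S)N2CCCCC2)coc2cc(Cl)ccc12`: 440 nM

The two measured compounds were tested in a functional assay on HeLa cells (Homo sapiens) for antiproliferative activity, read by MTT assay, with a stated time of 72 h; on this read-out lower numbers stand for stronger inhibition and higher numbers for weaker inhibition. Compound 1 gives 5900 nM there, and compound 2 gives 440 nM. Among the compounds with values here, compound 2 thus stands at the lower of the two numbers, with compound 1 the only neighbour, and the gap between them lies well beyond the scatter. Compound 1 and compound 2 differ in more than one place, so the gap cannot be traced to a single change; it can only be read as the two values show it.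

The next compound is compound 3, `O=c1c(CSC(=S)N2CCCCC2)coc2ccccc12`. It is derived from compound 2 by one change: hydrogen in place of chloro on an aromatic carbon. Within the data shown here, no step of this kind has been measured, so its size has to be guessed. Since compound 2 carries the chloro and gives the lower number, while compound 1, which lacks it, gives 5900 nM, a loss of some activity on removing the chloro is expected, though a modest one. The difference between compound 1 and compound 2 also includes another change, so their gap is not a measure of the chloro alone. Compound 3 is therefore expected to give about 1500 nM in this assay, within a range of 500 nM to 5000 nM, which means an estimated step of a 3.4-fold higher number from compound 2 to compound 3 (0.53 log units; beyond the scatter).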

Compound 3, half-maximal inhibitory concentration: 2300 nM
The estimate for compound 3 lay 1.5-fold (0.19 log units) below the measured number; the measured number falls inside the stated range.
By their numbers in this assay, from the lowest: compound 2; then compound 3; then compound 1.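

In this assay, the chloro on the aromatic carbon, meta to a fused ring and para to a fused ring, now has a step of its own: hydrogen in its place gives a 5.2-fold higher number from compound 2 to compound 3 (0.72 log units; beyond the scatter), whereas the earlier pair mixed this change with another. That other change can now also be read alone, with piperidin-1-yl in place of 4-methylpiperazin-1-yl on the thiocarbonyl carbon giving a 2.6-fold lower number from compound 1 to compound 3 (0.41 log units; beyond the scatter), so both changes separating compound 1 from compound 2 run toward the lower number, each on the strength of a single pair. No measurement at hand explains either step.

On these data alone, the chloro has been read only with piperidin-1-yl on the thiocarbonyl carbon, so it remains open whether the same change would carry a similar step with 4-methylpiperazin-1-yl in that place. As far as these compounds go, it is also open how fluoro, bromo or methoxy on the same aromatic carbon, or morpholin-4-yl on the thiocarbonyl carbon, would stand against chloro and piperidin-1-yl.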